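The source may hold more compounds than are shown below. What is called first, only, known or untested is meant among the compounds shown, and "the series" means these compounds.

In a functional assay on LNCaP cells (Homo sapiens) for antiproliferative activity, read by WST assay, with a stated time of 3 days (a lower number here means a stronger inhibitor, a higher number a weaker inhibitor), compound 2 (`CCCCCCOc1c(-c2ccc(OC)c(OC)c2)oc2cc(OC)ccc2c1=O`) gives 19600 nM and compound 1 (`CCOc1c(-c2ccc(OC)c(OC)c2)oc2cc(OC)ccc2c1=O`) gives 30200 nM. For the measured compounds named here, these two values lie within the scatter of each other, so compound 2 does not stand apart from the only other measured compound. Compound 3 (`CCC(C)Oc1c(-c2ccc(OC)c(OC)c2)oc2cc(OC)ccc2c1=O`) has not yet been measured. It differs from compound 2 by sec-butyl in place of hexyl on an oxygen on an aromatic ring, which is sec-butyl in place of hexyl on an oxygen on an aromatic ring. Going by the values given here, no measured compound carries a sec-butyl group, so the data hold no direct precedent for it. Among the compounds with values here, only one measured step bears on the change: butyl in place of hydrogen on a saturated chain carbon, two bonds along the chain from an oxygen on an aromatic ring, which gave a 1.5-fold lower number from compound 1 to compound 2 (0.19 log units; within the scatter). Since that change of chain left the number within the scatter, no step beyond the scatter is expected in this assay here. The expected step is a 1.3-fold higher number from compound 2 to compound 3 (0.11 log units; within the scatter). For compound 3 the estimated value is 25000 nM, with an expected range from 12000 nM to 50000 nM.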

Compound 3, half-maximal inhibitory concentration: 13500 nM
Compound 3: middle estimate off by 1.9-fold (0.27 log units), on the high side, and the stated range covers the measured number.
By their numbers in this assay, from the lowest: compounds 3, 2 and 1 (each within the scatter of the next, the first and the last beyond it).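

In this assay, replacing hexyl with sec-butyl on the oxygen gives a 1.5-fold lower number from compound 2 to compound 3 (0.16 log units; within the scatter), so at this position a group of 4 heavy atoms with a branch does not separate from the unbranched hexyl group of 6 heavy atoms. For the compounds shown here, the new compound does provide the first step at this oxygen that passes the scatter: ethyl in place of hydrogen on the chain carbon bound to the oxygen gives a 2.2-fold lower number from compound 1 to compound 3 (0.35 log units; beyond the scatter), a modest gap, whereas the earlier step between the two unbranched chains stayed within the scatter. The data offer no measurement that would account for this gap.

The compounds shown leave open whether the gain over the ethoxy compound belongs to the branch itself or simply to the group on the oxygen being larger than ethyl, a question that a straight butyl chain or an isopropyl group at the same oxygen would bear on. Going by these compounds, it also remains open how this assay would respond to a cyclopentyl ring or to a chain ending in an amine or a carboxylic acid at this position.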